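A few compounds are considered here, and "the series" means these few. Any claim that something is new, unique, unknown or untested is made for them only; others in the source may bear on it.

Measured so far:
compound 1 `O=C(/C=C/c1ccc(OCc2ccccc2)cc1)c1ccc(O)cc1O` — 9000 nM
compound 2 `COc1ccc(/C=C/C(=O)c2ccc(O)cc2O)cc1` — "not determined" (no result reported)

In a functional assay on A375-C5 cells (Homo sapiens) for inhibition, read by sulforhodamine B assay, with a stated time of 48 h (on this read-out lower numbers stand for stronger inhibition of growth and higher numbers for weaker inhibition of growth), compound 1 gives 9000 nM. For compound 2 the same assay records "not determined" (no result reported), so compound 2 stands without a number of its own; the only measured reference in this set is compound 1. Compound 3 `CCCc1c(O)ccc(C(=O)/C=C/c2ccc(OC)cc2)c1O` differs from compound 2 by propyl in place of hydrogen on an aromatic carbon. With no value for compound 2, the step to compound 3 in this assay cannot be anchored; a change no larger than the scatter, in either direction, is expected. Compound 3 is estimated at 10000 nM, with a range from 3000 nM to 40000 nM.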

Compound 3, concentration for 50% growth inhibition: 46300 nM
Compound 3: middle estimate off by 4.6-fold (0.67 log units), on the low side; measured number above the stated range.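

For the compounds shown here, no step from compound 2 to compound 3 can be read in this assay, where compound 2 has no number. The compounds shown leave open how propyl in place of hydrogen affects growth inhibition. No supporting evidence bears on this result.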